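The source may report more compounds than this note shows. Statements on the series, on what has been measured and on what is new or still open speak of the compounds shown alone.

Measured in an ADME assay on HepG2 cells (Homo sapiens) for cytotoxicity, with a stated time of 72 h; on this read-out lower numbers stand for an effect already at smaller amounts and higher numbers for an effect only at larger amounts of compound:
compound 1 `CC(=O)c1ccc(NC(=O)Nc2cc(C)nc3ccccc23)cc1`: 19000 nM
compound 2 `Cc1cc(NC(=O)Nc2ccc(C(N)=O)cc2)c2ccccc2n1`: > 25000 nM
compound 3 `Cc1cc(NC(=O)Nc2ccc(O)cc2)c2ccccc2n1`: > 25000 nM

Compound 3 reads > 25000 nM, which is a limit of this assay and not a number. It stands at the limit of > 25000 nM in this assay, at which 2 of the 3 values shown sit, so only a floor is known for it.

Compound 4 `Cc1cc(NC(=O)Nc2ccc(Cl)cc2)c2ccccc2n1` is not yet measured. It differs from compound 3 in one place: chloro in place of hydroxy on an aromatic carbon. This is chloro in place of hydroxy on an aromatic carbon, para to a large group.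

Within the data shown here, three measured steps bear on this carbon or its neighbouring series. The first is an at least 1.3-fold higher number from compound 1 to compound 3 (0.11 log units; that floor lies within the scatter), and the second is an at least 1.3-fold higher number from compound 1 to compound 2 (0.11 log units; that floor lies within the scatter). The third, a step that the two limits leave unreadable from compound 2 to compound 3, gives no size at all. None of them therefore shows a step beyond the scatter, and chloro itself has not been seen in the series.

Of the groups tried at this position, only acetyl has given a measured number, with compound 1 at 19000 nM. A result for chloro in that region is therefore expected, though the limit remains quite possible. The expected change is an at least 1.5-fold lower number from compound 3 to compound 4 (0.19 log units; that floor lies within the scatter), estimated as a modest move towards a lower number, perhaps none beyond the scatter. For compound 4 the estimate is 16000 nM, with an expected range from 6000 nM to 32000 nM.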

Compound 4, half-maximal effective concentration: > 25000 nM
Compound 4: a limit, no number (the forecaster's own chance of this, stated with the estimate: 40%); at least 1.5-fold (0.19 log units) between middle value and limit.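

In this assay compound 4 also reads > 25000 nM, which is a limit of the assay and not a number. Chloro, which carries no hydrogen-bond donor or acceptor, thus joins hydroxy and carbamoyl at this position in giving no number, and the values of the series now gather at a single point: the limit of > 25000 nM in this assay, at which 3 of the 4 values shown sit. Among these compounds, the only step that can be read is an at least 1.3-fold higher number from compound 1 to compound 4 (0.11 log units; that floor lies within the scatter), so exchanging acetyl for chloro shows no difference beyond the scatter, while the steps to compound 4 from compound 2 and from compound 3 cannot be read, as both ends of each are limits.

Acetyl in compound 1, at 19000 nM, therefore remains the only group at this position with a measured value, and it stays open whether an amine, a carboxylic acid or a longer chain there would give a number, and whether that number would lie clearly apart from that of compound 1. Going by these compounds, how far compound 2, compound 3 and compound 4 lie from one another also stays open, since the limits give no order among them.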